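The compounds below may be only part of what the source reports. "The series", "measured", "known", "first", "only" and "open" are said of these compounds alone.

The study turns on four closely related compounds that share one core, differing only in the group on an amide-type nitrogen in a ring and in the aryl group on a saturated ring carbon. Compound 1 `CN1C[C@@H](c2cccs2)[C@@]2(Cc3ccccc3C2=O)[C@@]12C(=O)Nc1ccccc12`, compound 2 `CN1C(=O)[C@@]2(c3ccccc31)N(C)C[C@@H](c1cccs1)[C@@]21Cc2ccccc2C1=O` and compound 3 `COc1ccc([C@@H]2CN(C)[C@]3(C(=O)N(C)c4ccccc43)[C@]23Cc2ccccc2C3=O)cc1` have been measured in a functional assay on the whole organism (strain Wister albino) for inhibition, with Rattus norvegicus as the target, read by paw edema, with stated times of 1 h and 3 h, at a dose of 50 mg/kg by the intraperitoneal route; a higher number here means more inhibition at the dose given (going by the name of the read-out), a lower number less inhibition. In this assay compound 1 gives 32.6%, compound 2 gives 9.1% and compound 3 gives 3.3%.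

Two changes have been tried. The first, (hydrogen in place of methyl on an amide-type nitrogen in a ring), brought a number 23.5 percentage points higher from compound 2 to compound 1 (beyond the scatter). The second, (4-methoxyphenyl in place of thiophen-2-yl on a saturated ring carbon), brought a number 5.8 percentage points lower from compound 2 to compound 3 (within the scatter); this second change is how the core of compound 2 differs from the core of compound 3.

Compound 4 `COc1ccc([C@@H]2CN(C)[C@]3(C(=O)Nc4ccccc43)[C@]23Cc2ccccc2C3=O)cc1` has not yet been measured in this assay. It differs from compound 3 by hydrogen in place of methyl on an amide-type nitrogen in a ring, which is the same change as that from compound 2 to compound 1, at a place described in identical words. Compound 4 is expected to land near 22% in this assay, with a plausible span from 5% to 40%. That estimate corresponds to an expected rise of a number 18.7 percentage points higher from compound 3 to compound 4 (beyond the scatter), and it rests on one observation only, because the same change gave a number 23.5 percentage points higher from compound 2 to compound 1 (beyond the scatter); whether a second aryl group carries the effect over is simply unknown until the number arrives.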

Compound 4, a percentage reported as inhibition, in the whole organism at one dose (the size of the read-out at that dose, not a potency): 20.5%
Compound 4: the middle estimate sits 1.5 percentage points above what was measured, and the stated range covers the measured number.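

Carrying the change from one core to the other held up in this assay: hydrogen in place of methyl on the amide-type nitrogen brought a number 17.2 percentage points higher from compound 3 to compound 4 (beyond the scatter), and the two steps agree with each other: the same change on two cores in this assay, a number 23.5 percentage points higher (beyond the scatter) from compound 2 to compound 1 and a number 17.2 percentage points higher (beyond the scatter) from compound 3 to compound 4, 6.3 percentage points apart, within the scatter of two such steps

The aryl change read the same way, since 4-methoxyphenyl in place of thiophen-2-yl on a saturated ring carbon brought a number 12.1 percentage points lower from compound 1 to compound 4 (beyond the scatter), and this too matches its counterpart on the other core: the same change on two cores in this assay, a number 5.8 percentage points lower (within the scatter) from compound 2 to compound 3 and a number 12.1 percentage points lower (beyond the scatter) from compound 1 to compound 4, 6.3 percentage points apart, within the scatter of two such steps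

So within these four compounds the two changes behave as close to additive, but this rests on a single pair of steps for each change, with only two aryl groups and two groups on the nitrogen, at one dose, which gives the size of the read-out and not a potency; it shows neither that the pattern extends to other aryl groups nor why the hydrogen gives the higher number.

The compounds shown leave open what an ethyl or benzyl group on the amide-type nitrogen would do. They also leave open how other groups on the saturated ring carbon, such as furan-2-yl or 4-chlorophenyl, would fare on either core.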